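Swapping the Basic Tail on a Shared Core

This account rests on a few compounds, and the source may have more. Where it says the series, first, only, none or still open, it means among the compounds named here.

Of the compounds shown here, three built on one shared core have been tested in a toxicity assay on L02 cells (Homo sapiens) for cytotoxicity, read by MTT assay, with a stated time of 72 h; a higher number here means a weaker inhibitor, a lower number a stronger inhibitor. Compound 1 `CN1CCN(CCCCCn2c3c(c4ccccc42)C(=O)c2c[n+]([O-])c4ccccc4c2C3=O)CC1` gives 1640 nM, the highest of the three numbers. Compound 2 `O=C1c2c[n+]([O-])c3ccccc3c2C(=O)c2c1c1ccccc1n2Cc1cn(CC(O)CO)nn1` gives 1070 nM, and compound 3 `O=C1c2c[n+]([O-])c3ccccc3c2C(=O)c2c1c1ccccc1n2Cc1cn([C@@H]2C[C@H](O)[C@@H](CO)O2)nn1` gives 630 nM. The move a 1.5-fold lower number from compound 1 to compound 2 (0.19 log units; within the scatter) and the move a 1.7-fold lower number from compound 2 to compound 3 (0.23 log units; within the scatter) each stay within the scatter, although compound 1 and compound 3 sit beyond the scatter from one another.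

Compound 4 `O=C1c2c[n+]([O-])c3ccccc3c2C(=O)c2c1c1ccccc1n2CCCN1CCC(O)CC1` has not yet been measured. It differs from compound 1 in one place: 4-hydroxypiperidin-1-yl in place of 2-(4-methylpiperazin-1-yl)ethyl on a saturated chain carbon, three bonds along the chain from an aromatic nitrogen. Going by the values given here, only the step from compound 1 to compound 2 touches the same region, and that step replaces the whole chain rather than its outer end, so it is a loose guide at best; its size stayed within the scatter. Among the compounds with values here, no measured pair shows the exact change to a hydroxypiperidine. The expected outcome for compound 4 is therefore a step of a 1.1-fold lower number from compound 1 to compound 4 (0.04 log units; within the scatter), with nothing beyond the scatter anticipated. Compound 4 is estimated at 1500 nM, in a range from 700 nM to 3200 nM.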

Compound 4, half-maximal inhibitory concentration: 120 nM
Beside the measured number, compound 4's estimate is 13-fold (1.10 log units) above it, outside the stated range (below it).
By their numbers in this assay, from the lowest: compound 4; then compounds 3, 2 and 1 (each within the scatter of the next, the first and the last beyond it).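

In this assay, going by these compounds alone, the group at the far end of the chain on the aromatic nitrogen matters more than the earlier steps suggested: a 14-fold lower number from compound 1 to compound 4 (1.14 log units; beyond the scatter), with 4-hydroxypiperidin-1-yl in place of 2-(4-methylpiperazin-1-yl)ethyl, is a step well beyond the scatter. The drop is not confined to that comparison, since an 8.9-fold lower number from compound 2 to compound 4 (0.95 log units; beyond the scatter), with 2-(4-hydroxypiperidin-1-yl)ethyl in place of 1-(2,3-dihydroxypropyl)-1H-1,2,3-triazol-4-yl, also lies beyond the scatter. No measurement available here explains these steps.

The change from 5-(4-methylpiperazin-1-yl)pentyl to 3-(4-hydroxypiperidin-1-yl)propyl alters the ring and the chain length together, and the compounds shown cannot separate the two. A plain piperidine without the hydroxyl group on the propyl chain, or a 4-methylpiperazine on that same chain, would help tell these contributions apart.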